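Chalcone triazole series: halogen swap on the benzyl arm

The source may report more compounds than this note shows. Statements on the series, on what has been measured and on what is new or still open speak of the compounds shown alone.

The three measured compounds share the bromophenyl enone and differ at the ether side. Compound 1 `C#CCOc1ccc(/C=C/C(=O)c2ccc(Br)cc2)cc1` carries a propargyl ether; in a functional assay on MCF7 cells (Homo sapiens) for inhibition, read by MTT assay, with a stated time of 48 h, tested at 10 uM (on this read-out higher numbers stand for more inhibition of growth at the one concentration tested and lower numbers for less inhibition of growth), compound 1 gives 45%. Compound 2 `O=C(/C=C/c1ccc(OCc2cn(Cc3ccccc3Br)nn2)cc1)c1ccc(Br)cc1` extends this into a triazole bearing a 2-bromobenzyl group, and in this assay compound 2 gives 44%. Compound 3 `O=C(/C=C/c1ccc(OCc2cn(Cc3cccc(Br)c3)nn2)cc1)c1ccc(Br)cc1` moves the bromine to the 3-position of that benzyl group; in this assay compound 3 gives 36%. Going by the values given here, the change a number 8 percentage points lower from compound 2 to compound 3 (within the scatter) is the only single-point step on record, and it lies within the scatter. Compound 3 thus sits at the bottom of the three figures, but both compound 2 and compound 1 fall within the usual scatter of it, so no ordering can be read from the numbers.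

Compound 4 `O=C(/C=C/c1ccc(OCc2cn(Cc3cccc(F)c3)nn2)cc1)c1ccc(Br)cc1` differs from compound 3 by fluoro in place of bromo on an aromatic carbon. Among the compounds with values here, no measured pair exchanges one halogen for another on this benzyl group, so the step from compound 2 to compound 3 bears only indirectly, and it was itself within the scatter. Nothing in the data points to a change beyond the scatter in this assay. Compound 4 is therefore expected to give 38%, within 25% to 51%; the expected step of a number 2 percentage points higher from compound 3 to compound 4 (within the scatter) is not beyond the scatter.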

Compound 4, percent growth inhibition at one concentration: 42%
Compound 4: the middle estimate sits 4 percentage points below what was measured; the range from low to high includes it.
By their numbers in this assay, from the lowest: compounds 3, 4, 2 and 1 (each within the scatter of the next).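

Going by these compounds alone, the first direct halogen exchange on this benzyl arm, fluoro in place of bromo on an aromatic carbon, gives in this assay (a number 6 percentage points higher from compound 3 to compound 4 (within the scatter)), so at this place the read-out does not separate the two halogens. The comparison with the 2-bromophenyl compound, 3-fluorophenyl in its stead, gives (a number 2 percentage points lower from compound 2 to compound 4 (within the scatter)), so this change of halogen and of its place on the ring also stays inside the usual spread of the read-out. No measured information is at hand that would explain these small differences.

With all four figures lying within the scatter of their neighbours, the series so far shows no handle on this arm that moves growth inhibition at the one concentration tested, and the halogens shown do not decide whether this place tolerates larger changes. On these data alone, whether an amine or a carboxylic acid in place of the fluoro on that aromatic carbon, or a longer chain in place of the benzyl link, would give a step beyond the scatter remains open.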